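Longer Cap on the Ring Nitrogen of Compound 3

The compounds below may be only part of what the source reports. "The series", "measured", "known", "first", "only" and "open" are said of these compounds alone.

Compound 1, `COc1ccc(-c2cnc3nc(N)nc(N4CCN(c5cc(Cl)cc(Cl)c5)CC4)c3n2)cc1OC`: in a functional assay on cells (T-cell, Homo sapiens) for inhibition (a lower number here means a stronger inhibitor, a higher number a weaker inhibitor), compound 1 gives 3400 nM.
Compound 2, `COc1ccc(-c2cnc3nc(N)nc(N4CCN(c5ccc(F)cc5)CC4)c3n2)cc1OC`: compound 2 gives 100 nM.
Compound 3, `COc1ccc(-c2cnc3nc(N)nc(N4CCN(c5ccc(C)cc5)CC4)c3n2)cc1OC`: compound 3 gives 300 nM.

Compound 3 stands second highest of the three numbers. Its nearest neighbour is compound 2, reached by a 3.0-fold higher number from compound 2 to compound 3 (0.48 log units; beyond the scatter); its furthest is compound 1, from which an 11-fold lower number from compound 1 to compound 3 (1.05 log units; beyond the scatter) leads to it.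

Compound 4, `COc1ccc(-c2cnc3nc(N)nc(N4CCN(Cc5ccc(C(C)(C)C)cc5)CC4)c3n2)cc1OC`, differs from compound 3 in one place: 4-(tert-butyl)benzyl in place of 4-methylphenyl on an amine nitrogen in a ring.

The measured steps of a 34-fold lower number from compound 1 to compound 2 (1.53 log units; beyond the scatter) and an 11-fold lower number from compound 1 to compound 3 (1.05 log units; beyond the scatter) show that exchanging the group on this ring nitrogen can shift the number strongly, yet none of them adds a tert-butyl or the extra carbon of a benzyl, so the direction here is uncertain. A modest weakening is expected, a 2.3-fold higher number from compound 3 to compound 4 (0.37 log units; beyond the scatter), giving an estimate for compound 4 of 700 nM, with a range from 120 nM to 4000 nM.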

Compound 4, half-maximal inhibitory concentration: 4300 nM
For compound 4 the middle estimate is 6.1-fold (0.79 log units) below the measured one; measured number above the stated range.
By their numbers in this assay, from the lowest: compound 2; then compound 3; then compounds 1 and 4 (each within the scatter of the next).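

In this assay this change costs far more than the swap of fluoro for methyl did: the step is a 14-fold higher number from compound 3 to compound 4 (1.16 log units; beyond the scatter) and, with the same group entering, a 43-fold higher number from compound 2 to compound 4 (1.63 log units; beyond the scatter) on the other side. The remaining step, a 1.3-fold higher number from compound 1 to compound 4 (0.10 log units; within the scatter), means that 4-(tert-butyl)benzyl and 3,5-dichlorophenyl on this ring nitrogen give readings that cannot be told apart. Nothing available here accounts for this result.

From the compounds shown here alone, compound 4 adds the benzyl carbon and the tert-butyl together, so which of the two matters stays open. A plain benzyl or a 4-(tert-butyl)phenyl group on this nitrogen would separate them.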